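The compounds below may be only part of what the source reports. "The series", "measured", "known", "first", "only" and "open" are said of these compounds alone.

In a functional assay on blood (Homo sapiens), with a stated time of 60 min, in the presence of a further agent that is not named here (a higher number here means that more compound is needed for the effect, a lower number that less compound is needed), compound 1 `CON(C)C(=O)C1(S(=O)(=O)c2ccc(Oc3ccc(OC(F)(F)F)cc3)cc2)CCC2(CCNCC2)C1` gives 3700 nM, and compound 3 `O=C(Oc1ccccc1)C1(S(=O)(=O)c2ccc(Oc3ccc(OC(F)(F)F)cc3)cc2)CCC2(CCNCC2)C1` gives 900 nM. Compound 2 `COC(=O)C1(S(=O)(=O)c2ccc(Oc3ccc(OC(F)(F)F)cc3)cc2)CCC2(CCNCC2)C1` gives only a limit of the assay, > 15000 nM. Compound 3 has the lowest number of the three, as shown by a 4.1-fold lower number from compound 1 to compound 3 (0.61 log units; beyond the scatter) and an at least 16-fold lower number from compound 2 to compound 3 (1.22 log units; beyond the scatter). Compound 4 `O=C1CN(C(=O)C2(S(=O)(=O)c3ccc(Oc4ccc(OC(F)(F)F)cc4)cc3)CCC3(CCNCC3)C2)CCN1` carries 3-oxopiperazin-1-yl in place of phenoxy on a carbonyl carbon, with 3-oxopiperazin-1-yl in place of phenoxy on a carbonyl carbon. Both measured replacements of phenoxy at that carbon left a higher number, a modest gap for compound 1 in a 4.1-fold lower number from compound 1 to compound 3 (0.61 log units; beyond the scatter) and a large one for compound 2 in an at least 16-fold lower number from compound 2 to compound 3 (1.22 log units; beyond the scatter). A modest to large rise is therefore expected, and the estimated step is a 3.9-fold higher number from compound 3 to compound 4 (0.59 log units; beyond the scatter). Compound 4 is expected at 3500 nM, within a range of 1200 nM to 12000 nM.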

Compound 4, half-maximal effective concentration: 7500 nM
Compound 4: middle estimate off by 2.1-fold (0.33 log units), on the low side; the range from low to high includes it.
By their numbers in this assay, from the lowest: compound 3; then compound 1; then compound 4. At a limit, above all of these: compound 2.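

Replacing phenoxy with a ring group of equal heavy-atom count did not hold the number down, an 8.3-fold higher number from compound 3 to compound 4 (0.92 log units; beyond the scatter), so compound 3 keeps the lowest number at this carbonyl carbon. The ring amide also fell behind the open methoxy(methyl)amino amide, a 2.0-fold higher number from compound 1 to compound 4 (0.31 log units; beyond the scatter), so amides at this position differ among themselves. Compound 2 has only a limit of the assay, which leaves an at least 2.0-fold lower number from compound 2 to compound 4 (0.30 log units; that floor lies within the scatter), and no firm size can be read from it: the limit of > 15000 nM in this assay, at which 1 of the 4 values shown sits.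

The compounds shown leave open whether a carboxylic acid or a primary amide at this carbon would behave differently. They also leave open whether a cyclohexyloxy group would keep the number of compound 3.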